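A few compounds are considered here, and "the series" means these few. Any claim that something is new, unique, unknown or untested is made for them only; others in the source may bear on it.

Among the compounds with values here, in a functional assay on HeLa cells (Homo sapiens) for inhibition, read by cell counting, with a stated time of 4 days (on this read-out higher numbers stand for weaker inhibition and lower numbers for stronger inhibition), compound 1 (`COc1ccc(N(C)c2nc(C)nc3c2nc(C)n3C)cc1`) gives 4500 nM, the only actual number among the measured compounds. Compound 2 (`COc1cccc(N(C)c2nc(C)nc3c2nc(C)n3C)c1`) reads > 250000 nM, which is a limit and not a number. Compound 3 (`Cc1nc(N(C)c2ccc(OC(F)(F)F)cc2)c2nc(C)n(C)c2n1`) keeps the core of compound 1 but has trifluoromethyl in place of methyl on an oxygen on an aromatic ring, a methoxy to trifluoromethoxy change: trifluoromethyl in place of methyl on an oxygen on an aromatic ring. Within the data shown here, no measured pair shows this change. In this assay a moderate weakening of inhibition beyond the scatter is expected, with an estimated step of a 3.3-fold higher number from compound 1 to compound 3 (0.52 log units; beyond the scatter). For compound 3 the expected value is 15000 nM, with an estimated range of 3000 nM to 80000 nM.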

Compound 3, half-maximal inhibitory concentration: 188000 nM
Compound 3: the middle estimate sits 13-fold (1.10 log units) below what was measured; measured number above the stated range.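

In this assay, the methyl on the oxygen on the aromatic ring cannot be exchanged for trifluoromethyl without a large loss of inhibition, with a 42-fold higher number from compound 1 to compound 3 (1.62 log units; beyond the scatter). Even so, compound 3 still gives an actual number, 188000 nM, and not a limit. That number leaves little room at the top of the read-out: the limit of > 250000 nM in this assay, at which 1 of the 3 values shown sits.

As far as these compounds go, whether a different group on this oxygen, such as an ethyl chain, would keep the inhibition of compound 1 stays open. The same holds for a free hydroxyl in place of the methoxy.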